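Removing the 2-carboxyethyl chain from compound 1

A few compounds are considered here, and "the series" means these few. Any claim that something is new, unique, unknown or untested is made for them only; others in the source may bear on it.

Compounds measured so far:
compound 1, `CC1(C)[C@@H]2CC3=N[C@@H](CCC(=O)O)C(=O)O[C@@]3(C)[C@H]1C2`: 36000 nM
compound 2, `CC1(C)[C@H]2CC3=N[C@H](CCC(=O)O)C(=O)O[C@]3(C)[C@@H]1C2`: 30000 nM
compound 3, `CC1(C)[C@@H]2CC3=NCC(=O)O[C@@]3(C)[C@H]1C2`: not yet measured

In a functional assay on EL4 cells (Mus musculus) for antiproliferative activity, read by sulforhodamine B assay, with a stated time of 48 h (a higher number here means a weaker inhibitor, a lower number a stronger inhibitor), compound 1 gives 36000 nM, the highest of the two numbers recorded. Compound 2 gives 30000 nM. Among the compounds with values here, the single measured step, a 1.2-fold lower number from compound 1 to compound 2 (0.08 log units; within the scatter), is within the scatter; the pair shares all atoms and bonds, and the fact that compounds 1 and 2 differ only in the configuration as drawn is all that separates them.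

Compound 3 differs from compound 1 by hydrogen in place of 2-carboxyethyl on a saturated ring carbon. Within the data shown here, no measured step changes atoms or bonds, so none bears directly on this change; the one step available concerns configuration only. Both measured compounds sit at weak inhibition, and the change in compound 3 removes the only chain carrying a hydrogen-bond donor. Compound 3 is therefore expected to give 60000 nM, with a wide range from 15000 nM to 250000 nM. The expected step is a 1.7-fold higher number from compound 1 to compound 3 (0.22 log units; within the scatter), with a real chance that only a limit is reported.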

Compound 3, half-maximal inhibitory concentration: 19000 nM
The estimate for compound 3 lay 3.2-fold (0.50 log units) above the measured number; low and high end bracket the measured number.
By their numbers in this assay, from the lowest: compounds 3, 2 and 1 (each within the scatter of the next).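

Hydrogen in place of 2-carboxyethyl, on the saturated ring carbon next to the ring nitrogen, gives in this assay a 1.9-fold lower number from compound 1 to compound 3 (0.28 log units; within the scatter). Within the data shown here, this is the first step that changes atoms and bonds rather than configuration, and it shows that the 2-carboxyethyl chain is not required for the antiproliferative reading: without it, compound 3 stays within the scatter of compound 1. Among these compounds, nothing measured so far accounts for this result.

From the compounds shown here alone, whether an amine or a longer chain on this ring carbon would move the number beyond the scatter remains open. Also open, going by these compounds, is whether any change at this position can give a reading clearly apart from those of compound 1 and compound 3.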